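Trimming a Side Chain: Tolerance Expected to Stay High

The source may hold more compounds than are shown below. What is called first, only, known or untested is meant among the compounds shown, and "the series" means these compounds.

Measured compounds:
Compound 1, `CCC1(Cc2ccccc2)OS(=O)(=O)C=C1OCC(=O)OC`, in an ADME assay on HEL cells (Homo sapiens) for cytotoxicity, with a stated time of 3 days (a higher number here means that more compound is tolerated, a lower number that less compound is tolerated), gives > 200000 nM, which is a limit of the assay rather than a number.
Compound 2, `CCC1(Cc2ccccc2)OS(=O)(=O)C=C1OCC#N`, in this assay gives > 200000 nM, likewise a limit.
Compound 3, `CCC1(Cc2ccccc2)OS(=O)(=O)C=C1OCc1ccc(F)cc1`, in this assay gives > 50000 nM, again a limit.

Compound 3 therefore stands at a limit, and the two other values shown are limits as well (the limit of > 200000 nM in this assay, at which 2 of the 3 values shown sit, and (the limit of > 50000 nM in this assay, at which 1 of the 3 values shown sits)). Among the compounds with values here, none of the measured steps can be read: a step that the two limits leave unreadable from compound 1 to compound 2, a step that the two limits leave unreadable from compound 1 to compound 3 and a step that the two limits leave unreadable from compound 2 to compound 3 all sit between two limits, so their size is unknown.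

Compound 4, `CCC1(Cc2ccccc2)OS(=O)(=O)C=C1OC`, differs from compound 3 in one place: hydrogen in place of 4-fluorophenyl on a saturated chain carbon bound to an oxygen on an unsaturated carbon. Every change so far at this same position has left the compounds tolerated up to the highest concentration tested, so no readable step bears on this one. In this assay no step beyond the scatter is expected, and the most likely outcome is another limit.

Compound 4 is thus estimated to give 200000 nM in this assay, with a range from 50000 nM to 500000 nM. This corresponds to an expected step that the limit leaves unreadable from compound 3 to compound 4.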

Compound 4, half-maximal cytotoxic concentration: > 200000 nM
Compound 4: no number, only a limit; the forecaster's own chance of this, stated with the estimate: 85%; the middle value sits exactly at the limit.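

Compound 4, like compound 1, compound 2 and compound 3, stands at a limit rather than at a number, so none of the steps among these four compounds can be read. The compounds shown leave open where the half-maximal cytotoxic concentration of each one lies, and whether changing this side chain shifts it at all.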